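Cyclopropylamino to Cyclobutylamino at the Assay Limit

A few compounds are considered here, and "the series" means these few. Any claim that something is new, unique, unknown or untested is made for them only; others in the source may bear on it.

All compounds here were tested in an ADME assay on L1210/0 cells (Mus musculus) for cytotoxicity, with a stated time of 48 h; a lower number here means a stronger inhibitor, a higher number a weaker inhibitor. Compound 1 `COc1ccccc1-c1ncnc2c1ncn2C[C@@H]1C[C@H](O)c2ccccc21` gives > 200000 nM, which is a limit of the assay rather than a number. Compound 2 `OC[C@@H]1C[C@H](Cn2cnc3c(Cl)ncnc32)c2c(-c3ccccc3)nnc(-c3ccccc3)c21` gives > 200000 nM, also only a limit. Compound 3 `OC[C@@H]1C[C@H](Cn2cnc3c(NC4CC4)ncnc32)c2c(-c3ccccc3)nnc(-c3ccccc3)c21` gives > 200000 nM, again a limit and not a number. Within the data shown here, the single measured step, a step that the two limits leave unreadable from compound 2 to compound 3, cannot be read because of the limit of > 200000 nM in this assay, at which 3 of the 3 values shown sit. Compound 4 `OC[C@@H]1C[C@H](Cn2cnc3c(NC4CCC4)ncnc32)c2c(-c3ccccc3)nnc(-c3ccccc3)c21` differs from compound 3 by cyclobutyl in place of cyclopropyl on a nitrogen on an aromatic ring. Among the measured compounds shown here, no measured step tells what this change does, so no shift beyond the scatter is expected, and compound 4 is expected to remain at the limit. The expected step that the limit leaves unreadable from compound 3 to compound 4 is therefore essentially none. The estimate for compound 4 is 400000 nM, with a range from 150000 nM to 3000000 nM.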

Compound 4, half-maximal inhibitory concentration: 90800 nM
Beside the measured number, compound 4's estimate is 4.4-fold (0.64 log units) above it; the measured number lies below the stated range.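

In this assay, cyclobutyl in place of cyclopropyl on a nitrogen on an aromatic ring gives an at least 2.2-fold lower number from compound 3 to compound 4 (0.34 log units; beyond the scatter), so a change at this position can bring a compound of this series into measurable range. Cyclobutylamino in place of chloro on an aromatic carbon likewise gives an at least 2.2-fold lower number from compound 2 to compound 4 (0.34 log units; beyond the scatter), while the step with cyclopropylamino in that place cannot be read. Both printed sizes are minimum sizes only, because the starting compounds sit at a limit: the limit of > 200000 nM in this assay, at which 3 of the 4 values shown sit.

On these data alone, whether a larger ring such as cyclopentyl or an open butyl chain on that nitrogen would lower the number further remains open.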